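Cytotoxicity notes on the chromene hydrazide series

The source may report more compounds than this note shows. Statements on the series, on what has been measured and on what is new or still open speak of the compounds shown alone.

Measured so far: compound 1 `COc1ccc(C(=O)N/N=C/C2=Cc3ccccc3OC2c2ccccc2)cc1`, 90700 nM; compound 2 `O=C(N/N=C/C1=Cc2ccccc2OC1c1ccccc1)c1ccco1`, 11900 nM; compound 3 `O=C(N/N=C/C1=Cc2ccccc2OC1c1ccccc1)c1ccc(F)cc1`, 30900 nM.

In a toxicity assay on HEK-293T cells (Homo sapiens) for cytotoxicity, read by MTT assay, with a stated time of 72 h (a higher number here means a weaker inhibitor, a lower number a stronger inhibitor), compound 3 stands second highest of the three numbers; compound 2 is nearest, a 2.6-fold higher number from compound 2 to compound 3 (0.41 log units; beyond the scatter), and compound 1 furthest, a 2.9-fold lower number from compound 1 to compound 3 (0.47 log units; beyond the scatter). Compound 4 `Cc1nnsc1C(=O)N/N=C/C1=Cc2ccccc2OC1c1ccccc1` differs from compound 3 by 4-methyl-1,2,3-thiadiazol-5-yl in place of 4-fluorophenyl on a carbonyl carbon. The step that bears on it is the swap of a five-membered heteroaryl for the 4-fluorophenyl, seen in reverse as a 2.6-fold higher number from compound 2 to compound 3 (0.41 log units; beyond the scatter), and the larger 7.6-fold lower number from compound 1 to compound 2 (0.88 log units; beyond the scatter) points the same way. A modest lowering in this assay is therefore expected, a 2.1-fold lower number from compound 3 to compound 4 (0.31 log units; beyond the scatter). Compound 4 is estimated at 15000 nM, within 6000 nM to 40000 nM.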

Compound 4, half-maximal inhibitory concentration: 30200 nM
Compound 4: middle estimate off by 2.0-fold (0.30 log units), on the low side; the measured number falls inside the stated range.
By their numbers in this assay, from the lowest: compound 2; then compounds 4 and 3 (each within the scatter of the next); then compound 1.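

In these notes on this assay, 4-methyl-1,2,3-thiadiazol-5-yl on this carbonyl carbon gives no readable change from 4-fluorophenyl (a 1.0-fold lower number from compound 3 to compound 4 (0.01 log units; within the scatter)). A five-membered aromatic ring in this place therefore does not by itself bring the number down to that of the furan-2-yl compound (a 2.5-fold higher number from compound 2 to compound 4 (0.40 log units; beyond the scatter)). The 4-methoxyphenyl compound remains apart from the thiadiazole (a 3.0-fold lower number from compound 1 to compound 4 (0.48 log units; beyond the scatter)).

Open, on these data alone, is how a piperidine, or a phenyl carrying a carboxylic acid, would read on this carbonyl carbon. No measured evidence bears on the reason for these differences.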